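The source may hold more compounds than are shown below. What is called first, only, known or untested is meant among the compounds shown, and "the series" means these compounds.

Measured in a physicochemical assay for lipophilicity, read by mass spectrometry; on this read-out higher numbers stand for higher lipophilicity and lower numbers for lower lipophilicity:
compound 1 `CCc1cccc(NC(=O)C2Cc3cc(OC)c(OC)cc3C2=O)c1`: 3.11
compound 2 `COc1cccc(NC(=O)C2Cc3cc(OC)c(OC)cc3C2=O)c1`: 2.08
compound 3 `COc1ccccc1NC(=O)C1Cc2cc(OC)c(OC)cc2C1=O`: 2.08

Compound 3 stands level with compound 2, the two together lowest of the three, and the gap to the remaining compound is a number 1.03 log units lower from compound 1 to compound 3 (beyond the scatter). The next compound is compound 4 `COc1cc2c(cc1OC)C(=O)C(C(=O)Nc1ccccc1Br)C2`, with bromo in place of methoxy on an aromatic carbon, ortho to a large group: bromo in place of methoxy on an aromatic carbon. Going by the values given here, no measured compound carries bromo, so the evidence is indirect. Shifting the methoxy gave no change at the digits printed from compound 2 to compound 3 (within the scatter). Methoxy in place of ethyl gave a number 1.03 log units lower from compound 1 to compound 2 (beyond the scatter), the only measured exchange of this group for another. Leaving methoxy is therefore expected to give a large rise in this assay, somewhat smaller than that exchange. The expected step is a number 0.82 log units higher from compound 3 to compound 4 (beyond the scatter). For compound 4 the estimate is 2.9, with an expected range of 2.5 to 3.3.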

Compound 4, partition coefficient: 3.03
Beside the measured number, compound 4's estimate is 0.13 log units below it, within the range that was stated.
By their numbers in this assay, from the lowest: compounds 2 and 3 (each within the scatter of the next); then compounds 4 and 1 (each within the scatter of the next).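

Bromo in place of methoxy on this aromatic carbon gives a number 0.95 log units higher from compound 3 to compound 4 (beyond the scatter) in this assay, so exchanging the group here counts where shifting the methoxy gave no change at the digits printed from compound 2 to compound 3 (within the scatter) and no visible step. The 2-bromophenyl gives a number 0.95 log units higher from compound 2 to compound 4 (beyond the scatter) and, against the 3-ethylphenyl, a number 0.08 log units lower from compound 1 to compound 4 (within the scatter) so these two groups cannot be told apart on this read-out. No measurement at hand bears on the reason for this step.

Open, going by these compounds, is how an amine or a carboxylic acid would read on this aromatic carbon. Also open, on these data alone, is whether shifting the bromo would leave the number unchanged, as shifting the methoxy did.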